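A few compounds are considered here, and "the series" means these few. Any claim that something is new, unique, unknown or untested is made for them only; others in the source may bear on it.

Of the compounds shown here, three built on one shared core have been tested in an ADME assay on PANC-1 cells (Homo sapiens) for cytotoxicity, read by MTT assay; a lower number here means that less compound is tolerated, a higher number that more compound is tolerated. Compound 1 `Cc1nc(-c2cccnc2)sc1-c1nnc(-c2ccc([N+](=O)[O-])cc2)o1` returns a result that is a limit of the assay rather than a number: in this assay compound 1 gives > 100 ug/mL. Compound 2 `Cc1nc(-c2cccnc2)sc1-c1nnc(-c2cccc(Cl)c2Cl)o1` is likewise reported only as a limit, compound 2 giving > 100 ug/mL. Compound 3 `Cc1nc(-c2cccnc2)sc1-c1nnc(-c2ccccc2[N+](=O)[O-])o1` also stops at a limit, compound 3 giving > 100 ug/mL. Compound 2 thus stands at the limit of > 100 ug/mL in this assay, at which 3 of the 3 values shown sit. Within the data shown here, since none of the three has a true number, no step between them can be sized, and nothing here separates one from another.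

Compound 4 `Cc1nc(-c2cccnc2)sc1-c1nnc(-c2cccnc2)o1` is not yet measured. It differs from compound 2 in one place: pyridin-3-yl in place of 2,3-dichlorophenyl on an aromatic carbon. No measured step of this kind is shown, and with every value sitting at a limit there is no direction to read off. The expectation is that the step that the limit leaves unreadable from compound 2 to compound 4 stays within the usual scatter, in neither direction. Compound 4 is accordingly expected to give about 150 ug/mL, within a range from 60 ug/mL to 400 ug/mL, and most likely to be reported again only as a limit.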

Compound 4, half-maximal cytotoxic concentration: > 100 ug/mL
Compound 4 ended at the assay's limit; the forecaster's own chance of this, stated with the estimate: 80%; the middle value lies beyond the limit too.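

Compound 2 and compound 4 are each reported only as a limit in this assay, so the step between them cannot be read, and the same holds for all four compounds: the limit of > 100 ug/mL in this assay, at which 4 of the 4 values shown sit. Which change to the shared core, if any, would give a true number in this assay remains open, as does any ranking of the four compounds.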